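The source may report more compounds than this note shows. Statements on the series, on what has been measured and on what is new or still open speak of the compounds shown alone.

compound 1 `O=C(CCCCC(S)CCS)NO`: 5.96%
compound 2 `O=C(CCCCC(S)CCS)Nc1ccc([N+](=O)[O-])cc1`: 1.88%

Both compounds were tested in a functional assay on Bel-7402 cells (Homo sapiens) for inhibition, read by MTT assay, with a stated time of 24 h, tested at 0.1 ug/mL; on this read-out higher numbers stand for more inhibition of growth at the one concentration tested and lower numbers for less inhibition of growth. Compound 1, at 5.96%, stands within the usual scatter of compound 2, at 1.88%, so the two numbers cannot be told apart. The next compound to be tested is compound 3 `O=C(CCCCC(S)CCS)Nc1ccccn1`, which follows from compound 1 by one structural change. Pyridin-2-yl takes the place of hydroxy on an amide-type nitrogen (pyridin-2-yl in place of hydroxy on an amide-type nitrogen). Going by the values given here, no measured pair of compounds differing in one place is available to give the size of such a step, so the expectation rests on thin evidence. Compound 2 also carries an aromatic ring on that nitrogen, and its value of 1.88% lies within the scatter of compound 1. On that basis, no change beyond the scatter is expected in this assay, and no direction is favoured with any confidence. The expected step is a number 2 percentage points lower from compound 1 to compound 3 (within the scatter). For compound 3 the estimated value is 4%, with an expected range of 0% to 12%.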

Compound 3, percent growth inhibition at one concentration: "not active" (no number reported)
No number was reported for compound 3; the estimate stays without a comparison.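

In this assay, going by these compounds alone, compound 3 was reported as not active, without a number, so no step from compound 1 to compound 3 can be read. The compounds shown leave open how large a change pyridin-2-yl in place of hydroxy on the amide-type nitrogen brings. Nothing available here offers an explanation for this result.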